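Swapping the triazole aryl group in an inactive series

A few compounds are considered here, and "the series" means these few. Any claim that something is new, unique, unknown or untested is made for them only; others in the source may bear on it.

Measured so far in a functional assay on HCT-116 cells (Homo sapiens) for antiproliferative activity, read by MTT assay, with a stated time of 48 h; a higher number here means a weaker inhibitor, a lower number a stronger inhibitor:
Compound 1 `CCOc1ccc(-n2nncc2CN2C(=O)C3(C(C#N)=C(N)Oc4c(N)cc5nc6ccccc6nc5c43)c3ccccc32)cc1` gives > 50000 nM, a limit of this assay.
Compound 2 `N#CC1=C(N)Oc2c(N)cc3nc4ccccc4nc3c2C12C(=O)N(Cc1cnnn1-c1ccc([N+](=O)[O-])cc1)c1ccccc12` gives > 50000 nM, likewise a limit.

For the measured compounds named here, compound 2 therefore stands at the upper boundary of this assay, where every value so far sits (the limit of > 50000 nM in this assay, at which 2 of the 2 values shown sit). Going by the values given here, the only measured step is a step that the two limits leave unreadable from compound 1 to compound 2; both of its ends are limits, so its size cannot be read. Compound 3 `Cc1ccc(-n2nncc2CN2C(=O)C3(C(C#N)=C(N)Oc4c(N)cc5nc6ccccc6nc5c43)c3ccccc32)cc1C` differs from compound 2 by 3,4-dimethylphenyl in place of 4-nitrophenyl on an aromatic nitrogen. No readable step bears on this change, so compound 3 is expected to stay at the limit, with a step that the limit leaves unreadable from compound 2 to compound 3 not beyond the scatter. The estimate for compound 3 is 60000 nM, in the range 20000 nM to 200000 nM.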

Compound 3, half-maximal inhibitory concentration: > 50000 nM
Compound 3 ended at the assay's limit; the forecaster's own chance of this, stated with the estimate: 80%; the middle value does not contradict the limit.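

Compound 3 also sits at a limit of the assay, so its steps from compound 1 and from compound 2 cannot be read: the limit of > 50000 nM in this assay, at which 3 of the 3 values shown sit. On these data alone, how far apart these three compounds truly lie in this assay stays open, as does whether any group on this aromatic nitrogen can give a readable value.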